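Furan for thiophene on a pyridine core: a paired swap

The source may hold more compounds than are shown below. What is called first, only, known or untested is meant among the compounds shown, and "the series" means these compounds.

Compound 1 `Oc1cccc(-c2cc(-c3ccccc3)cc(-c3ccsc3)n2)c1` gives 13800 nM in a functional assay on HeLa cells (Homo sapiens) for cytotoxicity, read by ELISA, with a stated time of 2 days; on this read-out lower numbers stand for stronger inhibition and higher numbers for weaker inhibition. Compound 2 `Oc1cccc(-c2cc(-c3ccccc3)cc(-c3ccco3)n2)c1` carries furan-2-yl in place of thiophen-3-yl on an aromatic carbon and gives 9430 nM in this assay, so that a 1.5-fold lower number from compound 1 to compound 2 (0.17 log units; within the scatter). Compound 3 `Oc1cccc(-c2cc(-c3ccccc3)nc(-c3ccsc3)c2)c1` has the same atoms as compound 1 joined differently; the difference between the two cores is not broken down here. In this assay compound 3 gives 14900 nM, which lies within the scatter of both compound 1 and compound 2. Compound 4 `Oc1cccc(-c2cc(-c3ccccc3)nc(-c3ccco3)c2)c1` carries furan-2-yl in place of thiophen-3-yl on an aromatic carbon, the same change, on the same place, as that from compound 1 to compound 2. Because a 1.5-fold lower number from compound 1 to compound 2 (0.17 log units; within the scatter), the step is expected to be of similar size, so that a 1.5-fold lower number from compound 3 to compound 4 (0.17 log units; within the scatter) is estimated. Compound 4 is therefore expected to give about 10000 nM in this assay, most likely between 5000 nM and 20000 nM.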

Compound 4, half-maximal inhibitory concentration: 10900 nM
The estimate for compound 4 lay 1.1-fold (0.04 log units) below the measured number; measured number inside the range.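

On the second core, furan-2-yl in place of thiophen-3-yl gives a 1.4-fold lower number from compound 3 to compound 4 (0.14 log units; within the scatter) in this assay. The swap thus carries from one core to the other at a like size: the same change on two cores in this assay, a 1.5-fold lower number (0.17 log units; within the scatter) from compound 1 to compound 2 and a 1.4-fold lower number (0.14 log units; within the scatter) from compound 3 to compound 4, 1.1-fold (0.03 log units) apart, within the scatter of two such steps. Going by these compounds alone, each step lies within the scatter, so the pair shows only that this swap changes little on either core; it does not show that furan-2-yl truly lowers the number, and so small a step is a weak test of transfer between cores.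

The compounds shown leave open what happens when the hydroxyl of the 3-hydroxyphenyl group is replaced. They also leave open whether an amine or a carboxylic acid in place of the five-membered ring would move the number beyond the scatter.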